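Swapping sulfur for selenium on a shared core

The source may hold more compounds than are shown below. What is called first, only, known or untested is meant among the compounds shown, and "the series" means these compounds.

Of the compounds shown here, three built on the same core have been tested in a functional assay on K562 cells (Homo sapiens) for cytotoxicity, read by MTT assay, with a stated time of 72 h; a higher number here means a weaker inhibitor of growth, a lower number a stronger inhibitor of growth. Compound 1 has the structure `CS/C(=N\C(=O)c1ccno1)NC(=O)c1ccno1`. In this assay compound 1 gives > 100000 nM, which is a limit of the assay rather than a measured number. Compound 3, with the structure `CS/C(=N\C(=O)c1ccco1)NC(=O)c1ccco1`, gives > 100000 nM in this assay, again a limit. Compound 2, with the structure `CS/C(=N\C(=O)c1cc2ccccc2s1)NC(=O)c1cc2ccccc2s1`, gives a measured number of 66600 nM in this assay. From the compounds shown here alone, compound 1 therefore sits where most of the set sits, at the limit of > 100000 nM in this assay, at which 2 of the 3 values shown sit, so its true potency is unknown beyond being weak.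

Compound 4 has the structure `C[Se]/C(=N\C(=O)c1ccno1)NC(=O)c1ccno1`. It differs from compound 1 in one place: a group of 2 heavy atoms (1 carbon, 1 selenium; no ring) in place of a group of 2 heavy atoms (1 carbon, 1 sulfur; no ring), on a carbon with a double bond to nitrogen. In words, a group of 2 heavy atoms (1 carbon, 1 selenium; no ring) takes the place of a group of 2 heavy atoms (1 carbon, 1 sulfur; no ring), on a carbon with a double bond to nitrogen.

Among the measured compounds shown here, no pair of measured compounds shows this change, so its effect has no direct reference here. Since compound 1 rests on a limit, any move can only be guessed; a step toward stronger growth inhibition of about an at least 1.4-fold lower number from compound 1 to compound 4 (0.15 log units; that floor lies within the scatter) is expected, though it may well stay within the scatter. For compound 4 the estimate in this assay is 70000 nM, with a likely range from 15000 nM to 100000 nM.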

Compound 4, concentration for total growth inhibition: 45600 nM
For compound 4 the middle estimate is 1.5-fold (0.19 log units) above the measured one; the measured number falls inside the stated range.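

On the shared core, the carbon with a double bond to nitrogen now proves to be a place where the assay responds to a change of a single element: in this assay, putting selenium in place of the sulfur of the methylsulfanyl group gives an at least 2.1-fold lower number from compound 1 to compound 4 (0.34 log units; beyond the scatter). Among the compounds shown here, the earlier compounds offered no comparison in one place, so this is the first step in the set that can be read, and it turns a compound that could only be placed at a limit into one with a measured number. The step gives a floor and not a full size, because compound 1 rests on a limit of the assay: the limit of > 100000 nM in this assay, at which 2 of the 4 values shown sit.

For the compounds shown here, only one pair carries this change, so it remains open whether selenium would shift the numbers in the same way on the benzene-fused or furan-bearing compounds, compound 2 and compound 3, or whether the shift belongs to this one pair alone. From the compounds shown here alone, it is also open whether selenium itself matters or whether other groups on this carbon, such as a longer chain on the sulfur or an amine, would give a similar or a larger step.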